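This account rests on a few compounds, and the source may have more. Where it says the series, first, only, none or still open, it means among the compounds named here.

Values in a functional assay on HOS-TE85 cells (Homo sapiens) for inhibition, read by CCK-8 assay, with a stated time of 72 h; on this read-out lower numbers stand for stronger inhibition and higher numbers for weaker inhibition:
- compound 1 `CCN(CC)c1ccc(N2C(=O)CSC2c2cccc(C(=O)NCCCCc3ccccc3)c2)cc1`: > 1000 nM
- compound 2 `O=C(NCCCCc1ccccc1)c1cccc(C2SCC(=O)N2c2ccccc2)c1`: 15.9 nM
- compound 3 `O=C(NCCCCc1ccccc1)c1cccc(C2SCC(=O)N2c2cccc(F)c2)c1`: 32.4 nM

The entry for compound 1 is a limit of the assay, not a number. Of the two true numbers, compound 3 holds the higher at 32.4 nM, and compound 2 the lower at 15.9 nM. Compound 4 `O=C(NCCCCc1ccccc1)c1cccc(C2SCC(=O)N2c2nccs2)c1` has 1,3-thiazol-2-yl in place of 3-fluorophenyl on an amide-type nitrogen in a ring. Changes to the group on this nitrogen have moved this assay by differing amounts. The step of a 2.0-fold higher number from compound 2 to compound 3 (0.31 log units; beyond the scatter) was modest, whereas an at least 62-fold lower number from compound 1 to compound 2 (1.79 log units; beyond the scatter) and an at least 30-fold lower number from compound 1 to compound 3 (1.48 log units; beyond the scatter) were large, and both of those involve the diethylamino group, which is absent here. A modest step to a higher number is therefore expected, as the nearest guide is a 2.0-fold higher number from compound 2 to compound 3 (0.31 log units; beyond the scatter). The expected change is a 2.2-fold higher number from compound 3 to compound 4 (0.33 log units; beyond the scatter). Compound 4 is estimated at 70 nM, with an expected range of 15 nM to 300 nM.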

Compound 4, half-maximal inhibitory concentration: > 1000 nM
Compound 4 ended at the assay's limit; the forecaster's own chance of this, stated with the estimate: 10%; at least 14-fold (1.15 log units) between middle value and limit.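

On the amide-type nitrogen in a ring, a large change in this assay no longer depends on a diethylamino group: 1,3-thiazol-2-yl gives an at least 30-fold higher number from compound 3 to compound 4 (1.48 log units; beyond the scatter) and an at least 62-fold higher number from compound 2 to compound 4 (1.79 log units; beyond the scatter). Replacing a six-membered aromatic ring of carbon only with this five-membered aromatic ring is therefore not tolerated in the way the fluoro change was. Compound 4 stands at a limit of the assay, as does compound 1, and the step between them cannot be read: the limit of > 1000 nM in this assay, at which 2 of the 4 values shown sit.

The compounds shown do not separate the effect of ring size from that of the ring nitrogen and sulfur. A thiophen-2-yl or pyridin-2-yl group on this nitrogen would bear on that question.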